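This account rests on a few compounds, and the source may have more. Where it says the series, first, only, none or still open, it means among the compounds named here.

Compounds measured in a functional assay on CCRF-CEM cells (Homo sapiens), read by MTT assay, with a stated time of 72 h; a lower number here means a stronger inhibitor, a higher number a weaker inhibitor:
- compound 1, `C#Cc1cn([C@@H]2O[C@H](CO)[C@@H](O)[C@H]2O)c2ncnc(C)c12`: 5600 nM
- compound 2, `Cc1ncnc2c1c(-c1cc3ccccc3o1)cn2[C@@H]1O[C@H](CO)[C@@H](O)[C@H]1O`: 17300 nM
- compound 3, `Cc1ncnc2c1c(-c1ccsc1)cn2[C@@H]1O[C@H](CO)[C@@H](O)[C@H]1O`: 11200 nM

Compound 2 gives the highest of the three numbers in this assay. Its nearest neighbour is compound 3, with a 1.5-fold lower number from compound 2 to compound 3 (0.19 log units; within the scatter), while the gap to compound 1 is larger, with a 3.1-fold higher number from compound 1 to compound 2 (0.49 log units; beyond the scatter). The remaining measured step, a 2.0-fold higher number from compound 1 to compound 3 (0.30 log units; within the scatter), lies within the scatter.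

Compound 4, `CNc1ncnc2c1c(-c1cc3ccccc3o1)cn2[C@@H]1O[C@H](CO)[C@@H](O)[C@H]1O`, is not yet measured. It differs from compound 2 at one place: methylamino in place of methyl on an aromatic carbon. None of the three measured steps touches this position; all of them exchange the group on the five-membered ring, with ethynyl, thiophen-3-yl or 1-benzofuran-2-yl. The effect of replacing methyl by methylamino therefore cannot be read from the measured steps. In the absence of any bearing step, a change of no more than the usual scatter in either direction is expected, so compound 4 is estimated at 15000 nM in this assay, within a range of 3000 nM to 60000 nM. The expected step of a 1.2-fold lower number from compound 2 to compound 4 (0.06 log units; within the scatter) is set near zero, with wide uncertainty.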

Compound 4, half-maximal inhibitory concentration: > 20000 nM
Compound 4: no number, only a limit; the forecaster's own chance of this, stated with the estimate: 10%; middle value at least 1.3-fold (0.12 log units) from the limit.
By their numbers in this assay, from the lowest: compounds 1, 3 and 2 (each within the scatter of the next, the first and the last beyond it). At a limit, above all of these: compound 4.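

Compound 4 is the first compound shown that changes the aromatic carbon opposite the ring nitrogen, since every earlier step exchanged the group on the five-membered ring. In this assay, its reading is a limit of the assay and not a number: the limit of > 20000 nM in this assay, at which 1 of the 4 values shown sits. The step, an at least 1.1-fold higher number from compound 2 to compound 4 (0.06 log units; that floor lies within the scatter), has a floor within the scatter, so with 1-benzofuran-2-yl held constant, methylamino in place of methyl brought no measurable gain, and any loss cannot be sized.

The compounds shown leave open how a plain amino group, a methoxy group or a longer chain would read at this carbon. They also leave open whether methylamino in place of methyl would give the same result with ethynyl, as in compound 1, or with thiophen-3-yl, as in compound 3.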